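The source may hold more compounds than are shown below. What is called first, only, known or untested is meant among the compounds shown, and "the series" means these compounds.

Measured in a functional assay on MCF7 cells (Homo sapiens) for antiproliferative activity, read by MTT assay, with a stated time of 72 h; a lower number here means a stronger inhibitor, a higher number a weaker inhibitor:
- compound 1 `C/C=C/C(=O)Nc1cccc(Oc2nc(Nc3cccc(OC)c3)nc3c2CSCC3)c1`: 23400 nM
- compound 2 `C/C=C/C(=O)Nc1cccc(Oc2nc(Nc3cccc(C#N)c3)nc3c2CSCC3)c1`: 21400 nM
- compound 3 `C=CC(=O)Nc1cccc(Oc2nc(Nc3ccc(OC)cc3)nc3c2CSCC3)c1`: 11700 nM

The value of compound 3 lies within the scatter of those of compound 1 and compound 2, so the three cannot be ranked in this assay. Compound 4 `C/C=C/C(=O)Nc1cccc(Oc2nc(Nc3ccc(OC)cc3)nc3c2CSCC3)c1` differs from compound 3 in one place: prop-1-en-1-yl in place of vinyl on a carbonyl carbon. This is prop-1-en-1-yl in place of vinyl on a carbonyl carbon.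

For the measured compounds named here, no measured pair isolates this change. Going by the values given here, the only measured step, a 1.1-fold lower number from compound 1 to compound 2 (0.04 log units; within the scatter), is cyano in place of methoxy on an aromatic carbon, a different change, and it stays within the scatter. Compound 1 and compound 2 carry prop-1-en-1-yl, while compound 3 carries vinyl, and their values show no gap beyond the scatter. No step beyond the scatter is therefore expected in this assay. The step expected is a 1.5-fold higher number from compound 3 to compound 4 (0.19 log units; within the scatter). For compound 4 the estimated value is 18000 nM, with an expected range from 9000 nM to 36000 nM.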

Compound 4, half-maximal inhibitory concentration: 24300 nM
Compound 4: middle estimate off by 1.4-fold (0.13 log units), on the low side; the measured number falls inside the stated range.
By their numbers in this assay, from the lowest: compounds 3, 2, 1 and 4 (each within the scatter of the next, the first and the last beyond it).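

In this assay, for the compounds shown here, the single change at the carbonyl carbon gives the first step in this set that lies beyond the scatter, though a modest one: prop-1-en-1-yl in place of vinyl, on a carbonyl carbon whose other neighbour is an amide-type nitrogen, gives a 2.1-fold higher number from compound 3 to compound 4 (0.32 log units; beyond the scatter). Changes to the aryl group on the nitrogen stay within the scatter, with 4-methoxyphenyl in place of 3-cyanophenyl giving a 1.1-fold higher number from compound 2 to compound 4 (0.06 log units; within the scatter) and 4-methoxyphenyl in place of 3-methoxyphenyl giving a 1.0-fold higher number from compound 1 to compound 4 (0.02 log units; within the scatter). Nothing at hand explains the step at the carbonyl carbon.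

On these data alone, this step rests on one pair, both members carrying 4-methoxyphenyl, so it remains open whether it holds with other aryl groups. Also open, as far as these compounds go, is how a longer chain, or a chain bearing an amine, would read at this carbonyl carbon.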